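A Rearranged Side Group on Compound 3

The source may report more compounds than this note shows. Statements on the series, on what has been measured and on what is new or still open speak of the compounds shown alone.

In a functional assay (aorta) for inhibition, with Rattus norvegicus as the target (on this read-out lower numbers stand for stronger inhibition and higher numbers for weaker inhibition), compound 1 `CCC/N=C(\S)[C@]1(c2cccnc2)CCCC[S+]1[O-]` gives 600 nM, and compound 2 `CC(C)/N=C(\S)[C@]1(c2cccnc2)CCCC[S+]1[O-]` gives 10000 nM. Compound 3 `CNC(=O)[C@]1(c2cccnc2)CCCC[S+]1[O-]` gives > 30000 nM, which is a limit of the assay and not a number. That places compound 3 at the weak end of the three. Compound 4 `COC(=N)[C@]1(c2cccnc2)CCCC[S+]1[O-]` holds the same atoms as compound 3, joined differently: a group of 4 heavy atoms (2 carbon, 1 nitrogen, 1 oxygen; no ring) in place of a group of 4 heavy atoms (2 carbon, 1 nitrogen, 1 oxygen; no ring), on a saturated ring carbon. The change lies on a saturated ring carbon, next to the ring sulfur.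

Two measured steps lead to this group of 2 carbon, 1 nitrogen, 1 oxygen atoms: an at least 50-fold higher number from compound 1 to compound 3 (1.69 log units; beyond the scatter) and an at least 3.0-fold higher number from compound 2 to compound 3 (0.47 log units; beyond the scatter). The first is large and the second at least modest, and both replace a group that holds sulfur. For the measured compounds named here, the group entering compound 4 holds no sulfur either, although no measured step tests this exact exchange. The expected result is no change beyond the scatter, with an estimated step of a number no higher from compound 3 to compound 4 (the limit leaves the size open). The estimated value for compound 4 is 30000 nM, with an expected range from 6000 nM to 150000 nM.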

Compound 4, concentration for 90% inhibition: > 30000 nM
Compound 4 gave a limit, no number; the forecaster's own chance of this, stated with the estimate: 60%; the middle value sits exactly at the limit.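

In this assay compound 4 sits at a limit of the assay, as compound 3 does, so the step between these two cannot be read: the limit of > 30000 nM in this assay, at which 2 of the 4 values shown sit. The sulfur-holding groups keep their distance from the new group, with an at least 50-fold higher number from compound 1 to compound 4 (1.69 log units; beyond the scatter) and an at least 3.0-fold higher number from compound 2 to compound 4 (0.47 log units; beyond the scatter). For the compounds shown here, on this saturated ring carbon, then, a second way of joining the same atoms also gives no readable number, so methylcarbamoyl is not the only group without sulfur to end at the limit.

The two limits leave methylcarbamoyl and the group of compound 4 unranked against each other. As far as these compounds go, it stays open whether any group without sulfur at this place, such as an amine or a carboxylic acid, would give a readable number, and how a longer chain on the double-bonded nitrogen would compare with the propyl of compound 1.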